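Swapping Chloro for Fluoro on the Aryl Ring

The compounds below may be only part of what the source reports. "The series", "measured", "known", "first", "only" and "open" are said of these compounds alone.

Of the compounds shown here, three have been tested in a functional assay on CHO cells for positive allosteric modulation of metabotropic glutamate receptor 2 (Homo sapiens), read by scintillation counting and GTPgammaS binding, with a stated time of 30 min; on this read-out higher numbers stand for larger maximal responses and lower numbers for smaller maximal responses. Compound 1 `COc1ccc(-c2ccn(CCC(C)C)c(=O)c2C#N)cc1F` gives 160%, and compound 2 `COc1ccc(-c2ccn(CCC(C)C)c(=O)c2C#N)cc1Cl` gives 200%. Compound 3 `CCCCn1ccc(-c2ccc(Oc3ccnc(C)c3)cc2Cl)c(C#N)c1=O`, whose core is built up differently, gives 187% in this assay .

Compounds 1 and 2 differ in a single place. The change is fluoro in place of chloro on an aromatic carbon, and in this assay it produced a number 40 percentage points lower from compound 2 to compound 1 (beyond the scatter). How the core of compound 3 differs from the core of compound 2 is not broken down here.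

Compound 4 `CCCCn1ccc(-c2ccc(Oc3ccnc(C)c3)cc2F)c(C#N)c1=O` has not yet been measured. It differs from compound 3 by fluoro in place of chloro on an aromatic carbon. Among the compounds with values here, this is the same kind of change as the one between compound 2 and compound 1, but not the same change: in compound 1 the fluoro sits ortho to a methoxy group and meta to a large group, whereas in compound 4 it sits ortho to a large group and meta to a (2-methylpyridin-4-yl)oxy group.

Because the earlier change gave a number 40 percentage points lower from compound 2 to compound 1 (beyond the scatter), a drop of a comparable size is expected here too, so compound 4 is estimated to show a number 37 percentage points lower from compound 3 to compound 4 (beyond the scatter) in this assay . Since the surroundings of the change are not identical, the expectation is held loosely. For compound 4 the estimated value in this assay is 150%, expected to fall between 115% and 185%.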

Compound 4, largest response reached (Emax), in percent of the reference or control that the assay uses: 232%
Compound 4: middle estimate off by 82 percentage points, on the low side; the whole stated range lies below it.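

In this assay, fluoro in place of chloro on an aromatic carbon gives a number 45 percentage points higher from compound 3 to compound 4 (beyond the scatter), which runs in the opposite direction to the earlier step. The result of this change therefore did not carry over from one core to the other, in either direction or size: the same change on two cores in this assay, a number 40 percentage points lower (beyond the scatter) from compound 2 to compound 1 and a number 45 percentage points higher (beyond the scatter) from compound 3 to compound 4, 85 percentage points apart, beyond the scatter of two such steps This does not show why the two steps part ways, since the two pairs differ both in their cores and in the groups around the changed carbon, and a single pair on each core cannot separate those differences, nor can it predict the step on any further core.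

The compounds shown leave open whether the rise seen with the (2-methylpyridin-4-yl)oxy group would survive if that group were replaced by a simple methoxy group, a swap that would show whether this group or the rest of the core decides the direction of the step. They also leave open how a bromo or a trifluoromethyl group on the same aromatic carbon would compare with chloro and fluoro on each of the two cores.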